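This account rests on a few compounds, and the source may have more. Where it says the series, first, only, none or still open, it means among the compounds named here.

Compound 1 `CN1CCN(Cc2ccc(NC(=O)Nc3ccc4ncnc(Nc5cccc(C(F)(F)F)c5)c4c3)cc2)CC1`: 1650 nM
Compound 2 `O=C(Nc1ccccc1)Nc1ccc2ncnc(Nc3cccc(C(F)(F)F)c3)c2c1`: > 10000 nM

Compound 2 stands at the weak end of what has been measured. In a functional assay on A549 cells (Homo sapiens) for antiproliferative activity, read by MTT assay, with a stated time of 72 h (on this read-out lower numbers stand for stronger inhibition and higher numbers for weaker inhibition), compound 2 gives > 10000 nM, which is a limit of the assay rather than a number. Compound 1 carries a (4-methylpiperazin-1-yl)methyl group where compound 2 has a hydrogen, and in this assay compound 1 gives 1650 nM. Compound 3 `Cc1ccc(NC(=O)Nc2ccc3ncnc(Nc4cccc(C(F)(F)F)c4)c3c2)cc1` differs from compound 2 by methyl in place of hydrogen on an aromatic carbon. Among the measured compounds shown here, the one measured step touching this position is an at least 6.0-fold higher number from compound 1 to compound 2 (0.78 log units; beyond the scatter); its size is known only as a lower bound because of the limit of > 10000 nM in this assay, at which 1 of the 2 values shown sits. For the measured compounds named here, a methyl is a much smaller group than the one removed in that step, so in this assay little movement is expected from it, quite possibly none beyond the scatter. Compound 3 is therefore estimated at 9000 nM, within 2500 nM to 30000 nM, an expected step of an at least 1.1-fold lower number from compound 2 to compound 3 (0.04 log units; that floor lies within the scatter).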

Compound 3, half-maximal inhibitory concentration: 4140 nM
Compound 3: the middle estimate sits 2.2-fold (0.34 log units) above what was measured; the range from low to high includes it.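

A single methyl on an aromatic carbon, para to a large group, is already enough to move the result in this assay, with an at least 2.4-fold lower number from compound 2 to compound 3 (0.38 log units; beyond the scatter). The size of that step is known only as a floor because compound 2 stands at a limit of the assay and not at a number: the limit of > 10000 nM in this assay, at which 1 of the 3 values shown sits.

Restoring the 4-methylpiperazin-1-yl on that methyl carbon goes further, with a 2.5-fold higher number from compound 1 to compound 3 (0.40 log units; beyond the scatter) read in the other direction, so the methyl accounts for part of the difference and the 4-methylpiperazin-1-yl adds more on top.

The compounds shown leave open whether another small group at this place, such as a chlorine atom or a methoxy, would do as much as the methyl. Also open, going by these compounds, is whether a different amine on the same carbon, such as morpholine or dimethylamine, would match the 4-methylpiperazin-1-yl.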